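Removing a Drawn Configuration from Compound 3

A few compounds are considered here, and "the series" means these few. Any claim that something is new, unique, unknown or untested is made for them only; others in the source may bear on it.

In a functional assay on HCT-116 cells (Homo sapiens) for inhibition (a higher number here means that more compound is needed for the effect, a lower number that less compound is needed), compound 1 `CC(C(=O)SCCCCCCC(=O)Nc1nc(-c2ccccc2)cs1)c1ccccc1` gives 23000 nM, compound 2 `C[C@H](Cc1ccccc1)C(=O)SCCCCCCC(=O)Nc1nc(-c2ccccc2)cs1` gives 750 nM, and compound 3 `C[C@@H](Cc1ccccc1)C(=O)SCCCCCCC(=O)Nc1nc(-c2ccccc2)cs1` gives 620 nM. Compound 3 therefore sits with compound 2 at the low end of these numbers, well away from compound 1. The large steps of a 31-fold lower number from compound 1 to compound 2 (1.49 log units; beyond the scatter) and a 37-fold lower number from compound 1 to compound 3 (1.57 log units; beyond the scatter) came with 1-benzylethyl in place of 1-phenylethyl on a carbonyl carbon, a change that plays no part in what follows. The next molecule is compound 4 `CC(Cc1ccccc1)C(=O)SCCCCCCC(=O)Nc1nc(-c2ccccc2)cs1`, and the change is this: the two compounds have the same atoms and bonds; at least one stereo element is drawn with a configuration in one of them and without one in the other: 1 of 1 stereo elements differ; a stereocentre at a saturated chain carbon is drawn S in compound 3 and without a configuration in compound 4. Within the data shown here, the one measured step that tests this stereocentre is a 1.2-fold lower number from compound 2 to compound 3 (0.08 log units; within the scatter), which lies within the scatter, given (the fact that compounds 2 and 3 differ only in the configuration as drawn). With that step as the guide, no change beyond the scatter is expected in this assay. The expected change is a 1.1-fold higher number from compound 3 to compound 4 (0.04 log units; within the scatter). For compound 4, the estimated value is 680 nM, with an expected range of 380 nM to 1200 nM.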

Compound 4, half-maximal effective concentration: 1200 nM
The estimate for compound 4 lay 1.8-fold (0.25 log units) below the measured number; the measured number falls inside the stated range.
By their numbers in this assay, from the lowest: compounds 3, 2 and 4 (each within the scatter of the next); then compound 1.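

In this assay, a 1.9-fold higher number from compound 3 to compound 4 (0.29 log units; within the scatter) and a 1.6-fold higher number from compound 2 to compound 4 (0.20 log units; within the scatter) both lie within the scatter, so the drawn S form, the drawn R form and the form without a drawn configuration now all sit within the scatter of one another: the fact that one of compounds 3 and 4 is drawn with a defined configuration and the other without, at the place where they differ The same holds for the other pair: the fact that one of compounds 2 and 4 is drawn with a defined configuration and the other without, at the place where they differ A second result is that compound 1 and compound 4 are both drawn without a configuration at this carbon, and a 19-fold lower number from compound 1 to compound 4 (1.28 log units; beyond the scatter) still gives a large step with benzyl in place of phenyl, so that gap does not rest on a comparison between a drawn and an undrawn structure.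

As far as these compounds go, whether a longer chain in place of benzyl would keep the numbers this low remains open. So does whether this stereocentre would count for as little with a 1-phenylethyl group or with that longer chain.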